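The source may report more compounds than this note shows. Statements on the series, on what has been measured and on what is new or still open speak of the compounds shown alone.

The three measured compounds share one core and differ only in the aryl group on a carbon with a double bond to nitrogen. Compound 1 `Cn1c(=O)c(=O)n(C2CCCC2)c2nc(N/N=C/c3ccc(F)cc3Cl)ncc21` gives 15200 nM in a functional assay on PC-3 cells (Homo sapiens) for antiproliferative activity, read by MTT assay; on this read-out lower numbers stand for stronger inhibition and higher numbers for weaker inhibition. Compound 2 `COc1ccc(/C=N/Nc2ncc3c(n2)n(C2CCCC2)c(=O)c(=O)n3C)c(OC)c1` reaches only the limit of this assay, > 100000 nM. That value is a limit (the limit of > 100000 nM in this assay, at which 1 of the 3 values shown sits). Compound 3 `Cn1c(=O)c(=O)n(C2CCCC2)c2nc(N/N=C/c3cccc(O)c3)ncc21` gives 36300 nM in this assay, the highest of the two numbers shown; its nearest neighbour is compound 1, as a 2.4-fold higher number from compound 1 to compound 3 (0.38 log units; beyond the scatter) shows. The other two comparisons, an at least 6.5-fold higher number from compound 1 to compound 2 (0.81 log units; beyond the scatter) and an at least 2.7-fold lower number from compound 2 to compound 3 (0.44 log units; beyond the scatter), are known only as bounds. Compound 4 `Cn1c(=O)c(=O)n(C2CCCC2)c2nc(N/N=C/c3ccc(O)c(Br)c3)ncc21` carries 3-bromo-4-hydroxyphenyl in place of 3-hydroxyphenyl on a carbon with a double bond to nitrogen. Among the compounds with values here, no measured step adds a bromine to a hydroxyphenyl; the three aryl swaps show only that this position moves the read-out by modest amounts, and the aryl group of compound 1, which bears two halogens, gave the lowest number. A modest step to a lower number is therefore expected in this assay, a 1.5-fold lower number from compound 3 to compound 4 (0.16 log units; within the scatter). Compound 4 is estimated at 25000 nM, with a range from 8000 nM to 80000 nM.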

Compound 4, half-maximal inhibitory concentration: 11600 nM
Beside the measured number, compound 4's estimate is 2.2-fold (0.33 log units) above it; the measured number falls inside the stated range.
By their numbers in this assay, from the lowest: compounds 4 and 1 (each within the scatter of the next); then compound 3. At a limit, above all of these: compound 2.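

In this assay, the step to 3-bromo-4-hydroxyphenyl gives the first lower number from compound 3, a 3.1-fold lower number from compound 3 to compound 4 (0.50 log units; beyond the scatter), so a hydroxyl-bearing aryl group at this position need not stay at the high end of the series. The second comparison, a 1.3-fold lower number from compound 1 to compound 4 (0.12 log units; within the scatter), shows that 2-chloro-4-fluorophenyl is no longer alone at the low end, since a group with a single halogen reads the same within the scatter. Compound 2 remains at a limit, so an at least 8.6-fold lower number from compound 2 to compound 4 (0.93 log units; beyond the scatter) is only a bound: the limit of > 100000 nM in this assay, at which 1 of the 4 values shown sits.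

The change adds a bromine and also moves the hydroxyl, and the compounds shown do not separate the two; a 4-hydroxyphenyl or a 3-bromophenyl group would. Going by these compounds, how an amine or a carboxylic acid on this aryl ring would read out also stays open.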